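The source may hold more compounds than are shown below. What is called first, only, known or untested is meant among the compounds shown, and "the series" means these compounds.

Measured in an ADME assay on Vero cells (Chlorocebus sabaeus) for cytotoxicity, read by MTT assay, with a stated time of 96 h; a higher number here means that more compound is tolerated, a lower number that less compound is tolerated:
- compound 1 (`CC(=O)c1ccc2[nH]c(-c3ccccc3)nc2c1`) gives > 100000 nM as a limit of the assay
- compound 2 (`CC(=O)c1ccc2c(c1)nc(-c1ccccc1)n2C1CCCCC1`) gives 80000 nM
- compound 3 (`CC(=O)c1ccc2c(c1)nc(-c1ccoc1)n2C1CCCCC1`) gives 80000 nM

Compound 3 stands level with its nearest neighbour, with no change at the digits printed from compound 2 to compound 3 (within the scatter) on the exchange of phenyl for furan-3-yl. The next structure is compound 4 (`CC(=O)c1ccc2[nH]c(-c3ccoc3)nc2c1`), which carries hydrogen in place of cyclohexyl on an aromatic nitrogen.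

The closest measured precedent is the same exchange in reverse on the phenyl members, with an at least 1.2-fold lower number from compound 1 to compound 2 (0.09 log units; that floor lies within the scatter) for the addition of cyclohexyl. Compound 1 stands at a limit (the limit of > 100000 nM in this assay, at which 1 of the 3 values shown sits), and the true size of that step is not known. Among the measured compounds shown here, the furan-3-yl exchange left this assay unmoved in the one pair measured, so the phenyl precedent is taken to carry over to the furan-3-yl members. Removing cyclohexyl is therefore expected to give a small move towards more compound tolerated, or none beyond the scatter. The expected change is a 1.3-fold higher number from compound 3 to compound 4 (0.10 log units; within the scatter) on this estimate. Compound 4 is expected at 100000 nM with an estimated range of 70000 nM to 150000 nM in this assay. A report as a limit alone is quite likely for this compound.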

Compound 4, half-maximal cytotoxic concentration: > 100000 nM
Compound 4 ended at the assay's limit; the forecaster's own chance of this, stated with the estimate: 60%; the middle value lies on the limit itself.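

In this assay, the removal of cyclohexyl from the aromatic nitrogen now has a second instance, on the furan-3-yl members, with an at least 1.2-fold higher number from compound 3 to compound 4 (0.09 log units; that floor lies within the scatter). The change therefore points the same way with phenyl and with furan-3-yl on the aromatic carbon, yet neither floor is shown to exceed the scatter: the same change on two cores in this assay, an at least 1.2-fold lower number (0.09 log units; that floor lies within the scatter) from compound 1 to compound 2 and an at least 1.2-fold lower number (0.09 log units; that floor lies within the scatter) from compound 4 to compound 3; the limit leaves it open whether they differ. Compound 4 now joins compound 1 as a limit rather than a number, so the furan-3-yl exchange on the hydrogen members cannot be read: the limit of > 100000 nM in this assay, at which 2 of the 4 values shown sit.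

Going by these compounds, the true size of the cyclohexyl step on either core remains open, as does whether that step differs between the phenyl and furan-3-yl members. Among the compounds shown here, also open is how this assay would read with a chain ending in an amine or a carboxylic acid on the same aromatic nitrogen, since compound 2 and compound 3 are the only members here with a substituent at that position that give a number rather than a limit.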